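The compounds below may be only part of what the source reports. "The series", "measured", "known", "first", "only" and "open" are said of these compounds alone.

Series notes. Compound 1 `Cc1cc(O)cc(-c2nn(CC#N)cc2-c2ccnc(-c3ccc(Oc4ccccc4)cc3)c2)c1` and compound 2 `COc1cc(C)cc(-c2nn(CC#N)cc2-c2ccnc(-c3ccc(N(C)C)cc3)c2)c1` share a core; in a functional assay on NCI-H322M cells (Homo sapiens) for cytotoxicity, read by sulforhodamine B assay, with a stated time of 48 h, tested at 100 nM (a lower number here means a stronger effect, a higher number a weaker effect of the compound at the concentration tested), compound 1 gives 95% and compound 2 gives 49%, so compound 2 stands lowest of the two, beyond the scatter from compound 1. Compound 3 `Cc1cc(O)cc(-c2nn(CC#N)cc2-c2ccnc(-c3ccc(N(C)C)cc3)c2)c1` differs from compound 2 by hydrogen in place of methyl on an oxygen on an aromatic ring. Going by the values given here, no pair differing only in this place has been measured, so the size and direction of the step in this assay are open. The step from compound 2 to compound 3 is expected to be modest, a number 13 percentage points higher from compound 2 to compound 3 (beyond the scatter), toward a weaker effect. For compound 3 the expected value in this assay is 62%, within 35% to 90%.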

Compound 3, a percentage reported as activity, at one concentration (the size of the read-out at that concentration, not a potency): 93%
Beside the measured number, compound 3's estimate is 31 percentage points below it, and the stated range ends below it.
By their numbers in this assay, from the lowest: compound 2; then compounds 3 and 1 (each within the scatter of the next).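

In this assay the oxygen on the aromatic ring proves a sensitive place: methoxy to hydroxy, with dimethylamino held constant, gives a number 44 percentage points higher from compound 2 to compound 3 (beyond the scatter) toward a weaker effect. Dimethylamino in place of phenoxy on an aromatic carbon, with hydroxy held constant, gives a number 2 percentage points lower from compound 1 to compound 3 (within the scatter) and so shows no readable change. Nothing available explains either step.

From the compounds shown here alone, whether ethoxy or an amine in place of methoxy would keep the effect seen for compound 2 remains open. So does whether methoxy would matter equally with phenoxy in place of dimethylamino.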